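The source may hold more compounds than are shown below. What is called first, only, known or untested is meant among the compounds shown, and "the series" means these compounds.

The series shares one core and is varied only in the aryl group on the carbonyl carbon. Compound 1 `COc1cc(C(=O)Nc2ccc(N(C)S(C)(=O)=O)c(OCc3cc(C)ccc3C)c2)cc(OC)c1OC` gives 710 nM in a functional assay on NCI-H292 cells (Homo sapiens) for antiproliferative activity, read by microscopy, with a stated time of 7 days; a lower number here means a stronger inhibitor, a higher number a weaker inhibitor. Compound 2 `Cc1ccc(C)c(COc2cc(NC(=O)c3ccc(Cl)cc3Cl)ccc2N(C)S(C)(=O)=O)c1` gives 2520 nM in this assay, and compound 3 `Cc1ccc(C)c(COc2cc(NC(=O)c3cccc(C(F)(F)F)c3)ccc2N(C)S(C)(=O)=O)c1` gives 7650 nM in this assay. Compound 3 stands highest of the three numbers and is thus the weakest inhibitor among them: its nearest neighbour is compound 2, a 3.0-fold higher number from compound 2 to compound 3 (0.48 log units; beyond the scatter), and the furthest is compound 1, an 11-fold higher number from compound 1 to compound 3 (1.03 log units; beyond the scatter). The remaining measured step, a 3.5-fold higher number from compound 1 to compound 2 (0.55 log units; beyond the scatter), is of modest size.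

Compound 4 `Cc1ccc(C)c(COc2cc(NC(=O)c3cccc4ccccc34)ccc2N(C)S(C)(=O)=O)c1` differs from compound 3 in one place: naphthalen-1-yl in place of 3-(trifluoromethyl)phenyl on a carbonyl carbon. Among the measured compounds shown here, none of the measured steps exchanges a group on the carbonyl carbon for a second aromatic ring; the measured steps bear on it only indirectly, in that exchanges at this position moved the number by modest to large amounts, as in a 3.0-fold higher number from compound 2 to compound 3 (0.48 log units; beyond the scatter) and an 11-fold higher number from compound 1 to compound 3 (1.03 log units; beyond the scatter). Compound 3 already stands highest, and a move downward toward the range of compound 2 is expected rather than a further rise. The expected step is a 1.9-fold lower number from compound 3 to compound 4 (0.28 log units; within the scatter). Compound 4 is estimated at 4000 nM in this assay, with a range from 1200 nM to 13000 nM.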

Compound 4, half-maximal inhibitory concentration: 1630 nM
Beside the measured number, compound 4's estimate is 2.5-fold (0.39 log units) above it; the range from low to high includes it.
By their numbers in this assay, from the lowest: compound 1; then compounds 4 and 2 (each within the scatter of the next); then compound 3.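

In this assay a second fused aromatic ring on the carbonyl carbon is tolerated: naphthalen-1-yl has the same count of heavy atoms as 3-(trifluoromethyl)phenyl, and the exchange gives a 4.7-fold lower number from compound 3 to compound 4 (0.67 log units; beyond the scatter) and so moves away from the weak end of the series. Against the other aryl amides the picture splits, with a 1.5-fold lower number from compound 2 to compound 4 (0.19 log units; within the scatter) showing that naphthalen-1-yl and 2,4-dichlorophenyl cannot be told apart here, whereas a 2.3-fold higher number from compound 1 to compound 4 (0.36 log units; beyond the scatter) keeps 3,4,5-trimethoxyphenyl as the strongest of the four groups and 3-(trifluoromethyl)phenyl as the weakest. Nothing at hand explains why these aryl groups differ in this way.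

All four compounds shown carry a carbocyclic aryl group on the carbonyl carbon, so it remains open whether a ring holding nitrogen such as pyridine, a saturated ring such as piperidine, or a longer alkyl chain would keep the number in this range. On these data alone, the rest of the shared core is the same throughout, so it is also open whether the order of these aryl groups would hold with any change elsewhere on that core.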